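Amide variation on the shared core: maximal response notes

The source may report more compounds than this note shows. Statements on the series, on what has been measured and on what is new or still open speak of the compounds shown alone.

Measured so far:
- Compound 1 `CSc1nc(-c2cccc(O)c2)c2c(N)c(C(=O)NC(C)(C)C)sc2n1` gives 63.9% in a functional assay on HEK293 cells for agonist activity at lutropin-choriogonadotropic hormone receptor (Homo sapiens), read by cAMP accumulation; on this read-out lower numbers stand for smaller maximal responses and higher numbers for larger maximal responses
- Compound 2 `COc1cccc(-c2nc(SC)nc3sc(C(=O)N(C)C(C)(C)C)c(N)c23)c1` gives 47.8% in this assay

Compound 2 stands lowest of the two numbers in this assay; its nearest neighbour is compound 1, whose value is higher by an amount beyond the usual scatter. Compounds 1 and 2 differ in more than one place, so no single step can be read between them; only the two values themselves are known.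

Compound 3 `COc1cccc(-c2nc(SC)nc3sc(C(=O)NNC(C)(C)C)c(N)c23)c1` is not yet measured. It differs from compound 2 by ((tert-butyl)amino)amino in place of methyl(tert-butyl)amino on a carbonyl carbon. Among the compounds with values here, with no step between measured compounds to lean on, the direction of this change is open. The expectation is a modest rise, a number 10.2 percentage points higher from compound 2 to compound 3 (beyond the scatter), with a wide margin in either direction. Compound 3 is estimated at 58% in this assay, with a range from 36% to 80%.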

Compound 3, largest response reached (reported as efficacy), in percent of the reference or control that the assay uses: 6%
Compound 3: the middle estimate sits 52 percentage points above what was measured, outside the stated range (below it).
By their numbers in this assay, from the lowest: compound 3; then compound 2; then compound 1.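

Notes on the carbonyl-carbon substituent: in this assay, ((tert-butyl)amino)amino in place of methyl(tert-butyl)amino comes with a number 41.8 percentage points lower from compound 2 to compound 3 (beyond the scatter), so this position is sensitive to the change. Both groups hold 6 heavy atoms, so matching that count does not keep the maximal response; the entering group differs in having one carbon fewer, one nitrogen more and 2 hydrogen-bond donors. No data at hand account for the drop.

Within the data shown here, compound 1 and compound 2 differ in more than one place, so no step between them can be read, and the single step here does not separate the contribution of the second nitrogen from that of the lost methyl. Going by these compounds, how a cyclohexylamino group or a longer alkyl chain on the carbonyl carbon would read out remains open.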